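Hept-1-en-1-yl for heptyl in a permeability series

A few compounds are considered here, and "the series" means these few. Any claim that something is new, unique, unknown or untested is made for them only; others in the source may bear on it.

Compound 1 `COc1ccc2[nH]c(C)c(Br)c(=O)c2c1` gives 16.7 10^-6 cm/s in an ADME assay for permeability, using PAMPA, at pH 7.4; a higher number here means that the compound crosses the layer faster, a lower number that the compound crosses the layer more slowly. Compound 2 `COc1cccc2c(=O)c(Cc3ccccc3)c(C)[nH]c12` gives 125 10^-6 cm/s in this assay. Compound 3 `CCCCCCCc1c(C)[nH]c2cc(OC)c(Cl)cc2c1=O` is reported in this assay only as a limit, < 0.01 10^-6 cm/s, and not as a number. Compound 3 thus sits at the floor of what this assay can report, the limit described in the limit of < 0.01 10^-6 cm/s in this assay, at which 1 of the 3 values shown sits. Compound 4 `CCCCC/C=C/c1c(C)[nH]c2cc(OC)c(Cl)cc2c1=O` differs from compound 3 in one place: hept-1-en-1-yl in place of heptyl on an aromatic carbon. Within the data shown here, no measured step covers this change, so in this assay a shift of no more than the scatter is expected, in no settled direction. For compound 4 the estimate is 0.02 10^-6 cm/s, within a range of 0.005 10^-6 cm/s to 0.3 10^-6 cm/s. The expected step is an at least 2.0-fold higher number from compound 3 to compound 4 (0.30 log units; that floor lies within the scatter), and a limit rather than a number remains the likelier outcome.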

Compound 4, apparent permeability: 46.3 10^-6 cm/s
Compound 4: the middle estimate sits 2300-fold (3.36 log units) below what was measured; the whole stated range lies below it.
By their numbers in this assay, from the lowest: compound 1; then compound 4; then compound 2. At a limit, below all of these: compound 3.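

Compound 3 is reported only as a limit: the limit of < 0.01 10^-6 cm/s in this assay, at which 1 of the 4 values shown sits. On this aromatic carbon, hept-1-en-1-yl in place of heptyl gives an at least 4600-fold higher number from compound 3 to compound 4 (3.66 log units; beyond the scatter) in this assay, the first step measured at this position. The two chains have the same count of heavy atoms, and the one double bond outside aromatic rings is the only difference between them.

On these data alone, how far the step extends beyond its stated minimum stays open. Also open, as far as these compounds go, is whether a similar step appears with a longer chain, or with an amine on the chain.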